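This account rests on a few compounds, and the source may have more. Where it says the series, first, only, none or still open, it means among the compounds named here.

In a functional assay on K562 cells (Homo sapiens), read by MTT assay, with a stated time of 72 h (a higher number here means a weaker inhibitor, a lower number a stronger inhibitor), compound 3 `C#Cc1cn([C@@H]2O[C@H](CO)[C@@H](O)[C@H]2O)c2ncnc(OC)c12` gives 300 nM, the highest of the three numbers in hand. Compound 2 `COc1ncnc2c1c(-c1ccoc1)cn2[C@@H]1O[C@H](CO)[C@@H](O)[C@H]1O` gives 190 nM, and compound 1 `COc1ncnc2c1c(-c1ccsc1)cn2[C@@H]1O[C@H](CO)[C@@H](O)[C@H]1O` gives 90 nM. Compound 3 is separated from compound 2 by a 1.6-fold higher number from compound 2 to compound 3 (0.20 log units; within the scatter), within the scatter, and from compound 1 by a 3.3-fold higher number from compound 1 to compound 3 (0.52 log units; beyond the scatter), beyond it.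

Compound 4 `COc1ncnc2c1c(-c1cc3ccccc3o1)cn2[C@@H]1O[C@H](CO)[C@@H](O)[C@H]1O` differs from compound 3 in one place: 1-benzofuran-2-yl in place of ethynyl on an aromatic carbon. Within the data shown here, two measured steps bear on a five-membered aromatic ring standing where ethynyl stands. The step of a 3.3-fold higher number from compound 1 to compound 3 (0.52 log units; beyond the scatter) shows thiophen-3-yl with a lower number than ethynyl, beyond the scatter; the step of a 1.6-fold higher number from compound 2 to compound 3 (0.20 log units; within the scatter) shows furan-3-yl with no difference beyond the scatter. Among the measured compounds shown here, no measured step covers a six-membered aromatic ring of carbon only fused to that five-membered ring, so that part of the change is untested. In this assay a modest lowering of the size seen for compound 1, or none beyond the scatter, is therefore expected. Compound 4 is estimated at 150 nM, with a range from 50 nM to 500 nM, which corresponds to an expected step of a 2.0-fold lower number from compound 3 to compound 4 (0.30 log units; within the scatter).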

Compound 4, half-maximal inhibitory concentration: 20900 nM
The estimate for compound 4 lay 140-fold (2.14 log units) below the measured number; the whole stated range lies below it.
By their numbers in this assay, from the lowest: compound 1; then compounds 2 and 3 (each within the scatter of the next); then compound 4.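

In this assay, among these compounds, the aromatic carbon bearing these groups proves far less permissive than the earlier compounds suggested: replacing the smaller groups with 1-benzofuran-2-yl gives a 70-fold higher number from compound 3 to compound 4 (1.84 log units; beyond the scatter), a 110-fold higher number from compound 2 to compound 4 (2.04 log units; beyond the scatter) and a 230-fold higher number from compound 1 to compound 4 (2.37 log units; beyond the scatter). Thiophen-3-yl, furan-3-yl and ethynyl had spanned no more than a 3.3-fold higher number from compound 1 to compound 3 (0.52 log units; beyond the scatter), so tolerance of two single five-membered aromatic rings and of ethynyl does not extend to this fused group of 9 heavy atoms. No available evidence accounts for the large rise in the number at this position.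

The step from compound 2 to compound 4 combines two changes, an added six-membered aromatic ring of carbon only and a shift from a 3-yl to a 2-yl attachment, and the compounds shown do not separate them. Open questions are how furan-2-yl, phenyl or 1-benzofuran-3-yl would read at this place, and therefore whether the fused ring alone carries the change or the attachment point contributes to it.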